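Methoxy for Methyl on the Aryl Ketone

The source may hold more compounds than are shown below. What is called first, only, known or untested is meant among the compounds shown, and "the series" means these compounds.

Compound 3 `COc1cc(-c2nnc3n2NC(c2cccs2)C(C(=O)c2ccc(C)cc2)S3)cc(OC)c1OC` gives 3700 nM in a functional assay on HepG2 cells (Homo sapiens) for cytotoxicity, read by MTT assay, with a stated time of 48 h (on this read-out higher numbers stand for weaker inhibition and lower numbers for stronger inhibition), and stands lowest of the two numbers shown, with compound 1 `COc1cc(-c2nnc3n2NC(c2ccco2)C(C(=O)c2ccccc2C)S3)cc(OC)c1OC` the nearest at 63000 nM. Compound 2 `COc1cc(-c2nnc3n2NC(c2ccco2)C(C(=O)c2ccccc2F)S3)cc(OC)c1OC` gives only a limit, > 100000 nM, a reading of the kind described by the limit of > 100000 nM in this assay, at which 1 of the 3 values shown sits. Within the data shown here, the one measured step on this ring, an at least 1.5-fold higher number from compound 1 to compound 2 (0.20 log units; that floor lies within the scatter), changed the same position but to a different group, so it says little about an added methoxy.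

Compound 4 `COc1ccc(C(=O)C2Sc3nnc(-c4cc(OC)c(OC)c(OC)c4)n3NC2c2cccs2)cc1` differs from compound 3 by methoxy in place of methyl on an aromatic carbon. Among the measured compounds shown here, with no step of this kind measured, compound 4 is expected to change by a 1.4-fold higher number from compound 3 to compound 4 (0.13 log units; within the scatter) in this assay, little beyond the scatter in either direction. Compound 4 is therefore estimated at 5000 nM, between 1500 nM and 17000 nM.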

Compound 4, half-maximal inhibitory concentration: 68000 nM
Estimate against measurement, compound 4: 14-fold (1.13 log units) below, and the stated range ends below it.
By their numbers in this assay, from the lowest: compound 3; then compounds 1 and 4 (each within the scatter of the next). At a limit, above all of these: compound 2.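

In this assay this position on the aryl ketone proves sensitive to a small exchange, with methoxy in place of methyl giving an 18-fold higher number from compound 3 to compound 4 (1.26 log units; beyond the scatter) in a single step. The earlier step on this ring could not show this, since its floor lay within the scatter, whereas this step lies well beyond it. Nothing at hand accounts for a step of this size.

From the compounds shown here alone, it remains open whether ethyl, chloro or a hydroxyl group at the same place would read like methyl or like methoxy. Going by these compounds, an amine there is equally open.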